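The compounds below may be only part of what the source reports. "The series", "measured", "known", "first", "only" and "open" are said of these compounds alone.

Measured so far:
- compound 1 `Cc1ccc(OCCCCN(Cc2ccc(C(=O)NO)cc2)c2ncc(-c3ccc(C)cc3)s2)cc1`: 8630 nM
- compound 2 `CCCCN(Cc1ccc(C(=O)NO)cc1)c1ncc(-c2ccc(C)cc2)s1`: 4780 nM
- compound 3 `Cc1ccc(OCCCN(Cc2ccc(C(=O)NO)cc2)c2ncc(-c3ccc(C)cc3)s2)cc1`: 32500 nM

All three were run in a functional assay on A549 cells (Homo sapiens) for antiproliferative activity, read by MTT assay, with a stated time of 48 h; on this read-out lower numbers stand for stronger inhibition of growth and higher numbers for weaker inhibition of growth. Compound 3 stands at the highest number of the three, beyond the scatter from both neighbours: a 3.8-fold higher number from compound 1 to compound 3 (0.58 log units; beyond the scatter) and a 6.8-fold higher number from compound 2 to compound 3 (0.83 log units; beyond the scatter).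

Compound 4 `Cc1ccc(-c2cnc(N(CCCCOc3ccccc3)Cc3ccc(C(=O)NO)cc3)s2)cc1` is not yet measured. Its difference from compound 3 is phenoxymethyl in place of 4-methylphenoxy on a saturated chain carbon, three bonds along the chain from a nitrogen on an aromatic ring. The two compounds hold the same atoms, joined differently, so that the chain runs one bond longer and the six-membered aromatic ring carries no methyl.

For the measured compounds named here, the only measured step that bears on this is the chain length: a 3.8-fold higher number from compound 1 to compound 3 (0.58 log units; beyond the scatter), where the shorter chain gave the higher number. Compound 4 carries the longer chain of compound 1, so on that ground a lower number than compound 3 is expected in this assay. Going by the values given here, no measured pair shows what removing the methyl from the aromatic ring does, so that part of the change is taken as neutral, with wider uncertainty.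

The step is therefore expected to be a 3.3-fold lower number from compound 3 to compound 4 (0.51 log units; beyond the scatter), and compound 4 is estimated at 10000 nM, with a range from 4000 nM to 25000 nM.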

Compound 4, concentration for 50% growth inhibition: 14200 nM
For compound 4 the middle estimate is 1.4-fold (0.15 log units) below the measured one; the measured number falls inside the stated range.
By their numbers in this assay, from the lowest: compounds 2, 1 and 4 (each within the scatter of the next, the first and the last beyond it); then compound 3.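

In this assay, rearranging the same atoms from the 3-(4-methylphenoxy)propyl chain to the 4-phenoxybutyl chain has a measurable effect at this saturated chain carbon (a 2.3-fold lower number from compound 3 to compound 4 (0.36 log units; beyond the scatter)), so the position responds to how the chain is joined and not only to its atom content. Hydrogen in place of methyl on the aromatic carbon stays inside the noise (a 1.6-fold higher number from compound 1 to compound 4 (0.22 log units; within the scatter)), which makes compounds 1 and 4 one level in this comparison, with the 4-phenoxybutyl type of chain tolerated with or without that methyl, although phenoxy in place of hydrogen at the chain end still separates compound 4 from the plain butyl chain of compound 2 (a 3.0-fold higher number from compound 2 to compound 4 (0.47 log units; beyond the scatter)). No measurement available here explains any of these shifts.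

Still open, going by these compounds, is whether the trend with chain length continues to a longer chain such as 5-phenoxypentyl, and whether 3-phenoxypropyl behaves like its methylated counterpart in compound 3. Also open, on these data alone, is how the chain end tolerates a different kind of group, such as a terminal morpholine or a carboxylic acid, in place of the phenoxy ring.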